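The source may report more compounds than this note shows. Statements on the series, on what has been measured and on what is new or still open speak of the compounds shown alone.

In an ADME assay on MT4 cells (Homo sapiens) for cytotoxicity, read by MTT assay, with a stated time of 5 days (on this read-out higher numbers stand for lower toxicity in this test and lower numbers for higher toxicity in this test), compound 1 `Cc1cc(OCC(=O)Nc2ccc(F)cc2)nc(Nc2ccc(C#N)cc2)n1` reads > 331000 nM as a limit of the assay, not a number. Compound 2 `Cc1cc(OCC(=O)Nc2ccc(Br)cc2)nc(Nc2ccc(C#N)cc2)n1` gives 930 nM and compound 3 `Cc1cc(OCC(=O)Nc2cccc(Cl)c2)nc(Nc2ccc(C#N)cc2)n1` gives 32200 nM as the higher of these two numbers. Compound 4 `Cc1cc(OCC(=O)Nc2ccc(C#N)cc2)nc(Nc2ccc(C#N)cc2)n1` is still unmeasured and carries 4-cyanophenyl in place of 3-chlorophenyl on an amide-type nitrogen. For the measured compounds named here, three measured steps bear on this change: (an at least 10-fold lower number from compound 1 to compound 3 (1.01 log units; beyond the scatter)), (a 35-fold higher number from compound 2 to compound 3 (1.54 log units; beyond the scatter)) and (an at least 350-fold lower number from compound 1 to compound 2 (2.55 log units; beyond the scatter)). All three are large, but they run in different directions and give no firm direction for the new group. The expected outcome is no shift beyond the scatter (a 1.3-fold lower number from compound 3 to compound 4 (0.11 log units; within the scatter)), though a large step either way remains possible. For compound 4 the estimated value is 25000 nM with an expected range from 3000 nM to 200000 nM in this test.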

Compound 4, half-maximal cytotoxic concentration: > 325000 nM
Compound 4 was reported as a limit (the forecaster's own chance of this, stated with the estimate: 25%); middle value at least 13-fold (1.11 log units) from the limit.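

In this assay compound 4 gives > 325000 nM, a limit of the assay and not a number. With 4-cyanophenyl on the amide-type nitrogen the series shows an at least 10-fold higher number from compound 3 to compound 4 (1.00 log units; beyond the scatter) and an at least 340-fold higher number from compound 2 to compound 4 (2.54 log units; beyond the scatter), so among the 4-substituted phenyl groups shown, the low number stays with 4-bromophenyl in compound 2 alone. Compound 1 and compound 4 both stand as limits, so the step between them cannot be read. Whether that low number belongs to bromo alone stays open, since 4-chlorophenyl and 4-iodophenyl on this nitrogen are not among the compounds shown. As far as these compounds go, how a carboxylic acid or an amine in that place would read also stays open.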